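The compounds below may be only part of what the source reports. "The series", "measured", "known", "first", "only" and "open" are said of these compounds alone.

In an assay on HEK293 cells for agonist activity at transient receptor potential cation channel subfamily M member 8 (Homo sapiens), read by fluorescence and calcium flux, with a stated time of 15 min (a higher number here means that more compound is needed for the effect, a lower number that less compound is needed), compound 1 `CCN(Cc1ccoc1)C(=O)COc1ccc(C)cc1` gives 136 nM, the lowest of the three numbers measured. Compound 2 `CCN(Cc1cccs1)C(=O)c1cc2cc(C)ccc2s1` gives 1600 nM in this assay, and compound 3 `CCCc1ccc(OCC(=O)N(CC)Cc2cccs2)cc1` gives 1810 nM, both well beyond the scatter from compound 1.

Compound 4 `CCN(Cc1cccn1C)C(=O)COc1ccc(C)cc1` differs from compound 1 by 1-methyl-1H-pyrrol-2-yl in place of furan-3-yl on a saturated chain carbon bound to an amide-type nitrogen. Within the data shown here, no measured pair shows this change on its own, and compound 3 differs from compound 1 in more than one place, so its value cannot be attributed to the ring alone. The step from compound 1 to compound 4 is therefore expected to be small, at most a modest rise, as a 1.8-fold higher number from compound 1 to compound 4 (0.26 log units; within the scatter). For compound 4 in this assay a value of 250 nM is estimated, expected to fall between 80 nM and 900 nM.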

Compound 4, half-maximal effective concentration: 21300 nM
The estimate for compound 4 lay 85-fold (1.93 log units) below the measured number, and the stated range ends below it.
By their numbers in this assay, from the lowest: compound 1; then compounds 2 and 3 (each within the scatter of the next); then compound 4.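

In this assay this position proves highly sensitive: 1-methyl-1H-pyrrol-2-yl in place of furan-3-yl gives a 160-fold higher number from compound 1 to compound 4 (2.19 log units; beyond the scatter) and is a large step for a single change. Both groups are five-membered aromatic rings with 1 hetero atom and the same counts of hydrogen-bond donors and acceptors, so these counts do not separate them. Nothing shown explains the size of this step. The compounds shown leave open how the step divides among the ring hetero atom, the methyl on nitrogen and the point of attachment. Furan-2-yl and 1H-pyrrol-2-yl at this position could help separate these.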